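Amino to carboxy on the shared core

The source may hold more compounds than are shown below. What is called first, only, known or untested is meant among the compounds shown, and "the series" means these compounds.

Measured in an ADME assay on Raji cells (Homo sapiens) for cytotoxicity, with a stated time of 72 h (on this read-out higher numbers stand for an effect only at larger amounts of compound and lower numbers for an effect already at smaller amounts), so far:
- Compound 1 `Cc1ccc(NC(=O)Nc2cc(C)nc3ccccc23)cc1` gives > 25000 nM (a limit)
- Compound 2 `Cc1cc(NC(=O)Nc2ccc(OC(F)(F)F)cc2)c2ccccc2n1` gives 10000 nM (a number)
- Compound 3 `Cc1cc(NC(=O)Nc2ccc(N)cc2)c2ccccc2n1` gives > 25000 nM (a limit)

Compound 3 stands at > 25000 nM (a limit, not a number). Compound 4 `Cc1cc(NC(=O)Nc2ccc(C(=O)O)cc2)c2ccccc2n1` has carboxy in place of amino on an aromatic carbon. Among the compounds with values here, no measured step involves carboxy. The nearest are an at least 2.5-fold higher number from compound 2 to compound 3 (0.39 log units; beyond the scatter) and an at least 2.5-fold lower number from compound 1 to compound 2 (0.39 log units; beyond the scatter) (both beyond the scatter), and both turn on trifluoromethoxy. The remaining one is a step that the two limits leave unreadable from compound 1 to compound 3 and gives nothing to go on. Compound 2 alone gives a number (10000 nM), so compound 4 is expected to stay close to compound 3, with no step beyond the scatter. The expected change is a number no higher from compound 3 to compound 4 (the limit leaves the size open) (an estimate). For compound 4 the estimate is 25000 nM (expected range 12000 nM to 50000 nM).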

Compound 4, half-maximal effective concentration: > 25000 nM
Compound 4: a limit, no number (the forecaster's own chance of this, stated with the estimate: 75%); the middle value lies on the limit itself.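

In this assay compound 4 gives > 25000 nM, which is a limit and not a number. Carboxy at this place therefore behaves like amino and methyl in giving no number, while trifluoromethoxy alone gives one, with an at least 2.5-fold higher number from compound 2 to compound 4 (0.39 log units; beyond the scatter). The steps to compound 4 from compound 1 and from compound 3 cannot be read, because both ends of each are limits: the limit of > 25000 nM in this assay, at which 3 of the 4 values shown sit.

On these data alone, how far compound 1, compound 3 and compound 4 lie beyond that limit stays open. So does whether a chlorine atom or a longer chain such as butoxy at this place would also give a number.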